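Furan-3-yl in place of thiophen-2-yl on the shared core

A few compounds are considered here, and "the series" means these few. Any claim that something is new, unique, unknown or untested is made for them only; others in the source may bear on it.

Compound 3 `COc1nc(N)nc2c1c(-c1cccs1)cn2[C@@H]1O[C@H](CO)[C@@H](O)[C@H]1O` stands at a limit in a functional assay on K562 cells (Homo sapiens), read by MTT assay, with a stated time of 72 h; on this read-out lower numbers stand for stronger inhibition and higher numbers for weaker inhibition: its reading is > 20000 nM, which is a limit of the assay rather than a number. Compound 2 `COc1nc(N)nc2c1c(-c1ccccc1)cn2[C@@H]1O[C@H](CO)[C@@H](O)[C@H]1O` likewise gives only the limit > 20000 nM. Compound 1 `COc1ncnc2c1c(-c1ccoc1)cn2[C@@H]1O[C@H](CO)[C@@H](O)[C@H]1O`, which lacks the amino group, gives 2820 nM. The step from compound 2 to compound 3 is a step that the two limits leave unreadable from compound 2 to compound 3, so its size is unreadable because of the limit of > 20000 nM in this assay, at which 2 of the 3 values shown sit. Compound 4 `COc1nc(N)nc2c1c(-c1ccoc1)cn2[C@@H]1O[C@H](CO)[C@@H](O)[C@H]1O` carries furan-3-yl in place of thiophen-2-yl on an aromatic carbon. Within the data shown here, no measured step reads the size of this swap, so the expectation in this assay rests on compound 3 sitting at the limit, and compound 4 is estimated at 20000 nM, between 5000 nM and 60000 nM, a step of a number no higher from compound 3 to compound 4 (the limit leaves the size open) expected to be no larger than the scatter.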

Compound 4, half-maximal inhibitory concentration: > 20000 nM
Compound 4: a limit, no number; the forecaster's own chance of this, stated with the estimate: 60%; the middle value sits exactly at the limit.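

In this assay, among these compounds, compound 4 supplies the first comparison that changes only the amino group, with furan-3-yl held fixed: amino in place of hydrogen on an aromatic carbon gives an at least 7.0-fold higher number from compound 1 to compound 4 (0.85 log units; beyond the scatter), so inhibition is weaker with the amino group. The swap of thiophen-2-yl for furan-3-yl, like the other ring swaps among compound 2, compound 3 and compound 4, cannot be read, because all three sit at one limit: the limit of > 20000 nM in this assay, at which 3 of the 4 values shown sit.

Going by these compounds, whether phenyl or thiophen-2-yl would give a measurable number without the amino group stays open. So does the outcome with a methyl group in place of the amino group.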